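A few compounds are considered here, and "the series" means these few. Any claim that something is new, unique, unknown or untested is made for them only; others in the source may bear on it.

Two compounds have been measured in a functional assay on PC-3 cells (Homo sapiens) for inhibition, read by sulforhodamine B assay, with a stated time of 48 h; a higher number here means a weaker inhibitor of growth, a lower number a stronger inhibitor of growth:
compound 1, `COc1ccc2[nH]c(-c3ccccc3)c(/C=C(\C#N)S(=O)(=O)c3ccccc3)c2c1`, gives 8300 nM;
compound 2, `N#C/C(=C\c1c(-c2ccccc2)[nH]c2ccccc12)S(=O)(=O)c1ccccc1`, gives 3400 nM.

Compound 2 gives the lower of the two numbers. Among the compounds with values here, the only other compound, compound 1, gives a higher one, and the step of a 2.4-fold lower number from compound 1 to compound 2 (0.39 log units; beyond the scatter), which comes from a hydrogen in place of methoxy on an aromatic carbon, lies beyond the scatter. Compound 3, `N#C/C(=C\c1c(-c2ccccc2)[nH]c2ccccc12)C(=O)c1ccccc1`, is not yet measured. It differs from compound 2 by benzoyl in place of phenylsulfonyl on a double-bonded chain carbon bound to a double-bonded chain carbon and a triple-bonded carbon. Within the data shown here, the one measured step, a 2.4-fold lower number from compound 1 to compound 2 (0.39 log units; beyond the scatter), concerns methoxy against hydrogen and says nothing about exchanging phenylsulfonyl for benzoyl; no measured step bears on this change. The expected step of no change at the digits printed from compound 2 to compound 3 (within the scatter) is accordingly none beyond the scatter, with a wide range to reflect the missing information. For compound 3 the estimate in this assay is 3400 nM, between 1000 nM and 12000 nM.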

Compound 3, concentration for 50% growth inhibition: 3500 nM
Compound 3: middle estimate off by 1.0-fold (0.01 log units), on the low side; measured number inside the range.
By their numbers in this assay, from the lowest: compounds 2 and 3 (each within the scatter of the next); then compound 1.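

In this assay, benzoyl in place of phenylsulfonyl on the double-bonded chain carbon gives a 1.0-fold higher number from compound 2 to compound 3 (0.01 log units; within the scatter) and so leaves the reading within the scatter. Within the data shown here, the earlier step concerned only methoxy against hydrogen on the core, so this is the only reading so far at this position, and it shows that in this pair a carbonyl can stand where the sulfonyl stood with no difference the assay can resolve, even though the two groups differ in their counts of heavy atoms and hydrogen-bond acceptors. No measurement at hand explains why the two groups read alike.

The compounds shown leave open whether a carboxylic acid or an amide at this place would also read alike. They also leave open whether methoxy on the core would give the same step with benzoyl as it does with phenylsulfonyl.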